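The source may hold more compounds than are shown below. What is called first, only, known or untested is meant among the compounds shown, and "the series" means these compounds.

Of the compounds shown here, two have been measured in an in vitro assay on BTI-TN-5B1-4 cells for inhibition of Amine oxidase [flavin-containing] A (Homo sapiens), read by fluorescence, with a stated time of 15 min, tested at 100 uM; a higher number here means more inhibition at the concentration tested (going by the name of the read-out), a lower number less inhibition. Compound 1, `Fc1ccc(-c2csc(N/N=C/c3ccccc3)n2)cc1`, gives 40%, and compound 2, `Fc1ccc(-c2csc(N/N=C/c3ccc(Cl)cc3)n2)cc1`, gives 40%. Among the measured compounds shown here, the single measured step, no change at the digits printed from compound 1 to compound 2 (within the scatter), shows that putting chloro in place of hydrogen on an aromatic carbon left the inhibition where it was. Compound 2 therefore stands level with compound 1, within the scatter of repeated measurements.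

Compound 3, `COc1ccc(/C=N/Nc2nc(-c3ccc(F)cc3)cs2)cc1`, has not yet been measured. It differs from compound 2 by methoxy in place of chloro on an aromatic carbon. For the measured compounds named here, no measured step tests methoxy; the only step that touches this position is the one that added chloro, and it was flat. On that basis the expected step in this assay, no change at the digits printed from compound 2 to compound 3 (within the scatter), is none beyond the scatter. Compound 3 is therefore estimated at 40% in this assay, with a likely range from 25% to 55%.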

Compound 3, a percentage reported as inhibition, at one concentration (the size of the read-out at that concentration, not a potency): 40%
Compound 3: the middle estimate sits on the measured number at the digits printed, and the stated range covers the measured number.
By their numbers in this assay, from the lowest: compounds 1, 2 and 3 (each within the scatter of the next).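

Until now, this position had only shown chloro against hydrogen. In this assay, methoxy, which brings an oxygen and a hydrogen-bond acceptor that chloro lacks, gives no change at the digits printed from compound 2 to compound 3 (within the scatter), and set against plain hydrogen it gives no change at the digits printed from compound 1 to compound 3 (within the scatter), so hydrogen, chloro and methoxy all read alike here at the single concentration tested. No measured evidence is available that would explain this flat result.

As far as these compounds go, whether a carboxylic acid, an amine or a longer chain at this same place would shift the inhibition remains open. A reading at one concentration is also not a potency, so the three compounds could still differ when compared across a range of concentrations.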